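The source may hold more compounds than are shown below. What is called first, only, known or untested is meant among the compounds shown, and "the series" means these compounds.

Measured so far:
- compound 1 `CCCNC(=O)[C@@H]1C[C@H]2CCC[C@@H](C1)[C@@H]2NC(=O)c1cc2scnc2n1Cc1ccc(OC)cc1`: > 25000 nM, a limit
- compound 2 `CCCNC(=O)[C@H]1[C@@H]2CCC[C@H]1CN(C(=O)c1cc3sc(-c4ccccc4)nc3n1Cc1ccc(OC)cc1)C2`: > 100000 nM, a limit

The read-out here is an ADME assay on HEK-293T cells (Homo sapiens) for cytotoxicity, read by luminescence and CellTiter-Glo, with a stated time of 24 h; on this read-out lower numbers stand for higher toxicity in this test and higher numbers for lower toxicity in this test. Compound 2 gives > 100000 nM, which is a limit of the assay and not a number. Compound 1 gives > 25000 nM, which is also a limit. Among the measured compounds shown here, neither compound therefore has a numerical value, and no measured step between compounds is available to size a change.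

Compound 3 `CCCNC(=O)[C@H]1[C@@H]2CCC[C@H]1CN(C(=O)c1cc3sc(Br)nc3n1Cc1ccc(OC)cc1)C2` has bromo in place of phenyl on an aromatic carbon of a five-membered aromatic ring with 1 nitrogen and 1 sulfur, part of a fused or bridged system of two rings: bromo in place of phenyl on an aromatic carbon. The rest of compound 2 is kept.

The expectation rests only on compound 2, whose limit is > 100000 nM. A modest move towards lower numbers is expected, and a result that is again only a limit is more likely than not. The expected change is an at least 1.4-fold lower number from compound 2 to compound 3 (0.15 log units; that floor lies within the scatter). For compound 3 the estimated value is 70000 nM, with an expected range of 25000 nM to 150000 nM.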

Compound 3, half-maximal cytotoxic concentration: 57500 nM
Compound 3: the middle estimate sits 1.2-fold (0.09 log units) above what was measured, within the range that was stated.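

In this assay, among the compounds shown here, compound 3 gives 57500 nM, the first reading at this position on the five-membered aromatic ring with 1 nitrogen and 1 sulfur that is a number and not a limit. Bromo in place of phenyl on this aromatic carbon gives an at least 1.7-fold lower number from compound 2 to compound 3 (0.24 log units; that floor lies within the scatter), so the change does not yet establish a real shift in toxicity in this test, although the true step may be larger than this floor. The full size of the step stays unknown because compound 2 carries a limit and not a number: the limit of > 100000 nM in this assay, at which 1 of the 3 values shown sits.

The compounds shown leave open whether a number at this position is particular to bromo or would also appear with a methyl, an amine or a carboxylic acid on the same aromatic carbon. They also leave open whether bromo in place of phenyl would give a similar step with other groups in the rest of the molecule, and a phenyl partner with a numerical value would be needed to size that step.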